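Cytotoxicity notes on a shared core with varied aryl groups

A few compounds are considered here, and "the series" means these few. Any claim that something is new, unique, unknown or untested is made for them only; others in the source may bear on it.

Measured compounds and values in a functional assay on HUVEC cells (Homo sapiens) for cytotoxicity; on this read-out lower numbers stand for an effect already at smaller amounts and higher numbers for an effect only at larger amounts of compound:
- compound 1 `COC1=C(C)C(=O)/C(=C(O)/C=C/c2ccc(OC)cc2)C(=O)C1(C)C` gives 2.5 ug/mL
- compound 2 `COC1=C(C)C(=O)/C(=C(O)/C=C/c2cccc(OC)c2)C(=O)C1(C)C` gives 1.6 ug/mL
- compound 3 `COC1=C(C)C(=O)/C(=C(O)/C=C/c2ccccc2C)C(=O)C1(C)C` gives 2.3 ug/mL

Compound 2 has the lowest of the three numbers, but the steps to compound 3 and to compound 1 are both within the scatter, so no order among the three can be claimed.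

The next compound to be measured is compound 4 `COC1=C(C)C(=O)/C(=C(O)/C=C/c2c(C)cccc2C)C(=O)C1(C)C`. Relative to compound 2 the change is 2,6-dimethylphenyl in place of 3-methoxyphenyl on a double-bonded chain carbon bound to a double-bonded chain carbon.

For the measured compounds named here, three measured steps bear on the aryl group at this place. a 1.6-fold lower number from compound 1 to compound 2 (0.19 log units; within the scatter). a 1.1-fold lower number from compound 1 to compound 3 (0.04 log units; within the scatter). a 1.4-fold higher number from compound 2 to compound 3 (0.16 log units; within the scatter). Every one of these is within the scatter, so exchanging one aryl group for another at this place has so far produced no step beyond the usual scatter. Compound 3, which carries a 2-methylphenyl group, is the closest structural comparator for the 2,6-dimethylphenyl group entering in compound 4, and its value sits within the scatter of compound 2.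

For compound 4 no step beyond the scatter is expected, so a 1.4-fold higher number from compound 2 to compound 4 (0.14 log units; within the scatter) is the estimated change. Compound 4 is therefore expected to give 2.2 ug/mL in this assay, with a range from 1 ug/mL to 4.8 ug/mL.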

Compound 4, concentration for half-maximal effect: 3 ug/mL
Compound 4: the middle estimate sits 1.4-fold (0.13 log units) below what was measured, and the stated range covers the measured number.
By their numbers in this assay, from the lowest: compounds 2, 3, 1 and 4 (each within the scatter of the next).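

In this assay, 2,6-dimethylphenyl, a group of carbon only, takes the place of the oxygen-bearing 3-methoxyphenyl (a 1.9-fold higher number from compound 2 to compound 4 (0.27 log units; within the scatter)) and 4-methoxyphenyl (a 1.2-fold higher number from compound 1 to compound 4 (0.08 log units; within the scatter)) groups, and both steps stay within the scatter, so the oxygen of these groups is not shown to matter on this read-out. The narrowest change at this place, methyl in place of hydrogen on an aromatic carbon (a 1.3-fold higher number from compound 3 to compound 4 (0.12 log units; within the scatter)), also stays within the scatter, so compound 3 and compound 4 cannot be told apart here. Nothing available accounts for how small these steps are.

All the aryl groups shown are phenyl rings carrying only methyl or methoxy, so it remains open whether a pyridine ring, or an amine or a carboxylic acid on the phenyl ring, would give a step beyond the scatter. Also open, going by these compounds, is how a longer chain between the aryl group and the shared core would read, and whether the flat picture at this place holds on any read-out other than this cytotoxicity measurement on one cell type.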